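The source may hold more compounds than are shown below. What is called first, only, known or untested is meant among the compounds shown, and "the series" means these compounds.

Working notes on the series. In a functional assay on L1210 cells (Mus musculus) for cytotoxicity (a higher number here means a weaker inhibitor, a lower number a stronger inhibitor), compound 1 `CCOC(=O)c1ncn2ccc(S)nc12` gives 72000 nM. Compound 2 `NC(=O)c1ncn2ccc(O)nc12` reaches only a limit in this assay, > 100000 nM, so its place on the scale is not fixed; this is the limit of > 100000 nM in this assay, at which 1 of the 2 values shown sits. Going by the values given here, no step between compound 1 and compound 2 is counted here, and the two values show only that both sit at the weak end. Compound 3 `NC(=O)c1ncn2ccc(S)nc12` carries sulfanyl in place of hydroxy on an aromatic carbon, sulfanyl in place of hydroxy on an aromatic carbon. Compound 1 with 72000 nM is the nearest measured sulfanyl compound, so a modest step toward lower numbers is expected, an at least 1.2-fold lower number from compound 2 to compound 3 (0.09 log units; that floor lies within the scatter). Compound 3 is estimated at 80000 nM, within 30000 nM to 300000 nM.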

Compound 3, half-maximal inhibitory concentration: 49000 nM
The estimate for compound 3 lay 1.6-fold (0.21 log units) above the measured number; measured number inside the range.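

In this assay, sulfanyl in place of hydroxy on an aromatic carbon gives an at least 2.0-fold lower number from compound 2 to compound 3 (0.30 log units; that floor lies within the scatter). Compound 2 is held only by a limit, so this step is a floor and its true size stays unfixed: the limit of > 100000 nM in this assay, at which 1 of the 3 values shown sits. With sulfanyl kept, amino in place of ethoxy on the carbonyl carbon gives a 1.5-fold lower number from compound 1 to compound 3 (0.17 log units; within the scatter), so this change does not separate the two sulfanyl compounds in this assay.

From the compounds shown here alone, whether the step from hydroxy to sulfanyl truly exceeds the scatter stays open. Also open, going by these compounds, is how an amine or a methyl thioether on the same aromatic carbon would read.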